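Piperidine nitrogen substituent variation on the spiro-indole core

The source may report more compounds than this note shows. Statements on the series, on what has been measured and on what is new or still open speak of the compounds shown alone.

Compound 2 `COc1ccc2[nH]c3c(c2c1)CCNC31CCN(Cc2cc(F)c(F)c(F)c2)CC1` stands lowest of the two numbers recorded so far in an assay on FRT cells for positive allosteric modulation of Cystic fibrosis transmembrane conductance regulator variant N1303K (Homo sapiens), in the presence of a further agent that is not named here; a lower number here means that less compound is needed, a higher number that more compound is needed for the effect; in this assay compound 2 gives 2600 nM. Its neighbour compound 1 `COc1ccc2[nH]c3c(c2c1)CCNC31CCN(Cc2cc(F)ccc2F)CC1` gives 11100 nM in this assay, and the step of a 4.3-fold lower number from compound 1 to compound 2 (0.63 log units; beyond the scatter) shows that the fluorine pattern on the benzyl ring alone moves the number well beyond the scatter. Compound 3 `COc1ccc2[nH]c3c(c2c1)CCNC31CCN(C(C)c2ccccc2)CC1` is the next member: 1-phenylethyl in place of 3,4,5-trifluorobenzyl on an amine nitrogen in a ring. Within the data shown here, no measured step covers the removal of all three fluorines together with branching at the saturated carbon, so the step from compound 1 to compound 2 is the only guide, and it suggests that the benzyl substitution matters. An upward step of modest size is therefore expected for compound 3, since it gives up the trifluorophenyl that carried the gain, a 2.7-fold higher number from compound 2 to compound 3 (0.43 log units; beyond the scatter). Compound 3 is estimated at 7000 nM, within 2500 nM to 25000 nM.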

Compound 3, half-maximal effective concentration: 20000 nM
Beside the measured number, compound 3's estimate is 2.9-fold (0.46 log units) below it, within the range that was stated.
By their numbers in this assay, from the lowest: compound 2; then compounds 1 and 3 (each within the scatter of the next).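

In this assay, 1-phenylethyl on the amine nitrogen in a ring gives a 7.7-fold higher number from compound 2 to compound 3 (0.89 log units; beyond the scatter), so losing 3,4,5-trifluorobenzyl at this position costs clearly more than the scatter. The change to 2,5-difluorobenzyl gives a 1.8-fold higher number from compound 1 to compound 3 (0.26 log units; within the scatter), so compound 3 and compound 1 cannot be told apart, and among these three groups only the 3,4,5-trifluorobenzyl of compound 2 stands apart. No measurement given here bears on the reason for this result.

Because the step to compound 3 removes the three fluorines and adds the methyl branch at once, the compounds shown leave open which of the two changes accounts for it. As far as these compounds go, a plain benzyl group would separate them, and a pyridylmethyl group on the same nitrogen remains open too.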